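The compounds below may be only part of what the source reports. "The series", "measured", "known", "first", "only" and "open" are said of these compounds alone.

Three hydroxamic acids built on one shared core have been measured for their effect on the growth of a human breast cancer cell line. Compound 1 `Cc1ccccc1CN1CC=C(CCC(=O)NO)C1=O` carries a methyl-substituted benzyl group on the ring nitrogen of that core, compound 3 `Cc1cccc(CN2CC=C(CCC(=O)NO)C2=O)c1` carries a benzyl group with the methyl in a different position, and compound 2 `O=C(CCC1=CCN(CCCc2ccc(Br)cc2)C1=O)NO` carries a three-carbon chain ending in a bromine-substituted phenyl ring. In a functional assay on MDA-MB-231 cells (Homo sapiens) for inhibition, read by sulforhodamine B assay (on this read-out higher numbers stand for weaker inhibition of growth and lower numbers for stronger inhibition of growth), compound 1 gives 1990 nM, compound 3 gives 1990 nM, and compound 2 gives 2210 nM. On paper compound 2 has the highest of the three figures, but both compound 1 and compound 3 sit within the usual scatter of it, so the three cannot be told apart by these numbers.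

Compound 4 `O=C(CCC1=CCN(CCCc2ccc(Cl)cc2)C1=O)NO` is the untested partner of compound 2. The difference between them is chloro in place of bromo on an aromatic carbon. Among the compounds with values here, no measured pair in this set shows what such an exchange does, so the expectation rests on the change itself, which swaps one halogen for another of the same kind at the same place. The estimated step from compound 2 to compound 4 is a 1.1-fold higher number from compound 2 to compound 4 (0.04 log units; within the scatter), which is no more than the scatter. Compound 4 is therefore expected to give about 2400 nM, with a likely range from 1200 nM to 5000 nM.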

Compound 4, concentration for 50% growth inhibition: 2210 nM
Beside the measured number, compound 4's estimate is 1.1-fold (0.04 log units) above it; low and high end bracket the measured number.
By their numbers in this assay, from the lowest: compounds 1, 3, 2 and 4 (each within the scatter of the next).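

Within the data shown here, replacing the 4-bromophenyl group with a 4-chlorophenyl group gives the first single-change step in this set: in this assay the step is no change at the digits printed from compound 2 to compound 4 (within the scatter) and it is the only direct comparison available so far. Among these compounds, it shows that, on this aromatic carbon para to a large group, exchanging bromo for chloro leaves growth inhibition in these cells without any difference that the measurement can detect, something the three earlier compounds could not show because no step connects them. Nothing available here explains why the two halogens read alike.

Bromo and chloro are close relatives, so this result says little about groups of a different kind at the same place, such as fluoro, methoxy, an amine or a carboxylic acid, or about a phenyl ring with no substituent at all. Among the compounds shown here, also open is whether the same exchange would read alike on a benzyl group like that of compound 1, or on a longer chain than the one in compound 2.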